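Swapping one carbon group on the compound 2 side chain

The compounds below may be only part of what the source reports. "The series", "measured", "known", "first", "only" and "open" are said of these compounds alone.

In a functional assay on HCT-116 cells (Homo sapiens) for antiproliferative activity, with a stated time of 96 h; a higher number here means a weaker inhibitor, a lower number a stronger inhibitor:
Compound 1 `CO[C@@H](C(=O)N[C@H]1CCc2ccccc2NC1=O)[C@H](O)[C@@H](O)[C@H](O)/C=C/C(C)(C)C`: 44 nM
Compound 2 `CO[C@@H](C(=O)N[C@H]1CC[C@@H](OC(=O)C2CCCCC2)CNC1=O)[C@H](O)[C@@H](O)[C@H](O)/C(C)=C/C(C)(C)C`: 140 nM

Compound 2 has the higher number of the two, with a gap to compound 1 that lies beyond the scatter. Compound 3 `CO[C@@H](C(=O)N[C@H]1CC[C@@H](OC(=O)C2CCCCC2)CNC1=O)[C@H](O)[C@@H](O)[C@H](O)/C=C/C(C)(C)C` differs from compound 2 in one place: a group of 6 heavy atoms (6 carbon; no ring) in place of a group of 7 heavy atoms (7 carbon; no ring), on a saturated chain carbon bound to an oxygen on a saturated carbon and a saturated chain carbon. A group of 6 heavy atoms replaces a group of 7 heavy atoms. Within the data shown here, no measured step isolates this change. Compound 1 carries the same 3,3-dimethylbut-1-en-1-yl group and gives 44 nM, so a moderate fall is expected in this assay. The expected change is a 3.5-fold lower number from compound 2 to compound 3 (0.54 log units; beyond the scatter). The estimated value for compound 3 is 40 nM, with an expected range of 12 nM to 130 nM.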

Compound 3, half-maximal inhibitory concentration: 23 nM
Beside the measured number, compound 3's estimate is 1.7-fold (0.24 log units) above it; measured number inside the range.
By their numbers in this assay, from the lowest: compounds 3 and 1 (each within the scatter of the next); then compound 2.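

In this assay, putting 3,3-dimethylbut-1-en-1-yl in place of the group of 7 heavy atoms gives a 6.1-fold lower number from compound 2 to compound 3 (0.78 log units; beyond the scatter), which isolates this change with the rest of the structure held constant. At this saturated chain carbon, the smaller of the two carbon groups therefore gives the lower number. Nothing measured here gives a reason for this step. As far as these compounds go, whether a longer chain, a phenyl ring or an amine would raise or lower the number at this place remains open, as does whether the step would hold on the core of compound 1.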